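Removing one hydroxy from compound 1 in this assay

The source may report more compounds than this note shows. Statements on the series, on what has been measured and on what is new or still open speak of the compounds shown alone.

Measured compounds:
compound 1 `O=C1c2c(O)cc(O)cc2O[C@@H](c2cc(O)ccc2O)[C@@H]1O` with 25400 nM
compound 2 `COc1ccc([C@@H]2Oc3cc(O)cc(O)c3C(=O)[C@H]2O)cc1` with > 100000 nM
compound 3 `O=C1c2c(O)cc(O)cc2O[C@H](c2cc(O)ccc2O)[C@H]1O` with 24500 nM

In a physicochemical assay, read by spectrophotometry, with a stated time of 30 min (on this read-out lower numbers stand for an effect already at smaller amounts and higher numbers for an effect only at larger amounts of compound), compound 1 gives 25400 nM, the highest of the two numbers reported, with compound 3 as its nearest neighbour at a 1.0-fold lower number from compound 1 to compound 3 (0.02 log units; within the scatter). For compound 2 the result is a limit, > 100000 nM, so no number is available for it. Within the data shown here, the only measured step, from compound 1 to compound 3, concerns configuration alone the fact that compounds 1 and 3 differ only in the configuration as drawn and does not touch the hydroxy groups; it therefore says little about the change to compound 4 `O=C1c2c(O)cc(O)cc2O[C@@H](c2cccc(O)c2)[C@@H]1O`, which is hydrogen in place of hydroxy on an aromatic carbon. What compound 2 shows is that a compound bearing a methoxy instead of the hydroxy pattern of compound 1 reached only the limit (the limit of > 100000 nM in this assay, at which 1 of the 3 values shown sits). On that basis compound 4 is expected to give a larger number than compound 1, a step of a 2.8-fold higher number from compound 1 to compound 4 (0.44 log units; beyond the scatter), with a real chance that only a limit is reported. The estimate for compound 4 is 70000 nM, with a range from 25000 nM to 200000 nM.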

Compound 4, half-maximal effective concentration: > 100000 nM
Compound 4: only a limit was reported; the forecaster's own chance of this, stated with the estimate: 40%; middle value at least 1.4-fold (0.15 log units) from the limit.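

In this assay, replacing the hydroxy on this aromatic carbon, ortho to a large group and para to a hydroxy group, with hydrogen gives an at least 3.9-fold higher number from compound 1 to compound 4 (0.59 log units; beyond the scatter), so the read-out depends on the hydroxy at this position. Compound 4 gives > 100000 nM, which is a limit of the assay and not a number, so the step has a lower bound but no known size. This is the first single-place step here to change a substituent, whereas the earlier step spoke only to configuration: the fact that compounds 1 and 3 differ only in the configuration as drawn

As far as these compounds go, how far beyond the limit compound 4 lies remains open, as does whether its mirror image would behave the same way. Also open, from the compounds shown here alone, is whether an amine or a carboxylic acid on this carbon would keep the number close to that of compound 1, 25400 nM.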